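From 3-azido-4-methoxyphenyl to 3,4,5-trimethoxyphenyl

The compounds below may be only part of what the source reports. "The series", "measured", "known", "first", "only" and "open" are said of these compounds alone.

In a functional assay on HCT-116 cells (Homo sapiens) for antiproliferative activity, read by MTT assay, with a stated time of 48 h (on this read-out lower numbers stand for stronger inhibition and higher numbers for weaker inhibition), compound 1 (`COc1ccc(CN(C(=O)CSc2nc3ccccc3s2)c2cc(OC)c(OC)c(OC)c2)cc1N=[N+]=[N-]`) gives 2860 nM, the highest number of the three measured and the weakest inhibition among them. Compound 2 (`COc1ccc(CN(C(=O)CSc2nc3ccccc3s2)c2cc(OC)c(OC)c(OC)c2)cc1`), with hydrogen in place of azido, gives 426 nM, and compound 3 (`COc1ccc(CN(C(=O)CSc2nc3ccccc3s2)c2cc(OC)c(OC)c(OC)c2)cc1O`), with hydroxy in place of azido, gives 182 nM. Compound 4 (`COc1cc(CN(C(=O)CSc2nc3ccccc3s2)c2cc(OC)c(OC)c(OC)c2)cc(OC)c1OC`) instead has 3,4,5-trimethoxyphenyl in place of 3-azido-4-methoxyphenyl on a saturated chain carbon bound to an amide-type nitrogen. It also loses the azido group, so two steps bear on it: a 6.7-fold lower number from compound 1 to compound 2 (0.83 log units; beyond the scatter), which is modest, and a 16-fold lower number from compound 1 to compound 3 (1.20 log units; beyond the scatter), which is large. Both lie beyond the scatter, but neither compound 2 nor compound 3 carries the entering group. A modest step towards a lower number is therefore expected in this assay. The expected change is a 5.7-fold lower number from compound 1 to compound 4 (0.76 log units; beyond the scatter). For compound 4 the estimated value is 500 nM, with an expected range of 150 nM to 1700 nM.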

Compound 4, half-maximal inhibitory concentration: 65300 nM
Compound 4: the middle estimate sits 130-fold (2.12 log units) below what was measured; the measured number lies above the stated range.
By their numbers in this assay, from the lowest: compound 3; then compound 2; then compound 1; then compound 4.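

The earlier compounds shown here showed only steps towards lower numbers at this place, but in this assay 3,4,5-trimethoxyphenyl on a saturated chain carbon bound to an amide-type nitrogen gives the first step upward (a 23-fold higher number from compound 1 to compound 4 (1.36 log units; beyond the scatter)), so losing azido does not by itself lower the number here. The gap is wider against the two compounds that lack azido (a 150-fold higher number from compound 2 to compound 4 (2.19 log units; beyond the scatter); a 360-fold higher number from compound 3 to compound 4 (2.55 log units; beyond the scatter)), which shows that the choice of aryl group at this place can matter more than any change seen among compounds 1 to 3. Nothing available explains this loss.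

The compounds shown leave open whether a single added methoxy group, as in 3,4-dimethoxyphenyl, is enough to raise the number. They also leave open whether an amine in place of azido would stay close to compound 3 or move towards compound 4.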